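This account rests on a few compounds, and the source may have more. Where it says the series, first, only, none or still open, it means among the compounds named here.

Compounds measured so far in an assay on CHO cells for displacement of a labelled ligand from adenosine receptor A3 (Homo sapiens), read by scintillation counting, tested at 10 uM; a lower number here means less inhibition, a higher number more inhibition at the concentration tested (going by the name of the read-out):
- compound 1, `CC(C)(C)Cc1csc(N)c1C(=O)c1cccc(Cl)c1`: 8%
- compound 2, `CC(C)(C)Cc1c(-c2ccoc2)sc(N)c1C(=O)c1ccc(Cl)cc1`: 1%
- compound 3, `CC(C)(C)Cc1c(Br)sc(N)c1C(=O)c1ccc(Cl)cc1`: 1%

Compound 3 stands level with compound 2 at the digits reported, and together they give the lowest two of the three numbers in this assay; compound 1 gives a number higher than compound 3, but the gap between them lies within the scatter. For the measured compounds named here, the one change that has been measured within this set, bromo in place of furan-3-yl on an aromatic carbon, gave no change at the digits printed from compound 2 to compound 3 (within the scatter), so that substitution left the read-out where it was.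

Compound 4, `CC(C)(C)Cc1c(Br)sc(N)c1C(=O)c1cccc(Cl)c1`, has not yet been measured. It differs from compound 3 in one place: 3-chlorophenyl in place of 4-chlorophenyl on a carbonyl carbon. Going by the values given here, no measured step covers this change directly. Compound 1, which also carries a 3-chlorophenyl on its carbonyl carbon, gives 8%, and compound 3 gives 1%; the difference between these two values lies within the scatter. Compound 4 is therefore expected to remain close to compound 3, with the change a number 2 percentage points higher from compound 3 to compound 4 (within the scatter) not expected to exceed the scatter. The estimate for compound 4 in this assay is 3%, with a range from -5% to 12%.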

Compound 4, a percentage reported as inhibition, at one concentration (the size of the read-out at that concentration, not a potency): 1%
The estimate for compound 4 lay 2 percentage points above the measured number; low and high end bracket the measured number.
By their numbers in this assay, from the lowest: compounds 2, 3, 4 and 1 (each within the scatter of the next).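

In this assay, 3-chlorophenyl in place of 4-chlorophenyl on a carbonyl carbon gave no change at the digits printed from compound 3 to compound 4 (within the scatter) and so left the read-out unmoved with bromo on the shared core. Bromo in place of hydrogen on an aromatic carbon, a change the earlier compounds did not cover as a single step, gave a number 7 percentage points lower from compound 1 to compound 4 (within the scatter) and so cannot be told from the scatter. With these two steps, all three single changes measured in this small set, on the aromatic carbon and on the carbonyl carbon, stay within the scatter.

Going by these compounds, it remains open whether an amine or a carboxylic acid in place of chlorine on the phenyl group, or a longer chain in place of bromo, would give a step beyond the scatter. No measurement here bears on why these changes left the read-out flat.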